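Bromo for methoxy on a chromone carboxamide scaffold

The source may report more compounds than this note shows. Statements on the series, on what has been measured and on what is new or still open speak of the compounds shown alone.

Measured so far:
compound 1, `O=C(NC1CCN(Cc2ccccc2)CC1)c1coc2ccccc2c1=O`, 17700 nM
compound 2, `O=C(NC1CCN(Cc2ccccc2)CC1)c1coc2ccc(OCc3ccccc3)cc2c1=O`, 35 nM
compound 3, `COc1ccc2c(=O)c(C(=O)NC3CCN(Cc4ccccc4)CC3)coc2c1`, 28600 nM

These three share one core and differ only in a single substituent on the benzo ring. In an assay on isolated protein for inhibition of Amine oxidase [flavin-containing] B (Homo sapiens), read by fluorescence and Amplex Red, with stated times of 15 min and 20 min (a higher number here means a weaker inhibitor, a lower number a stronger inhibitor), compound 3 gives 28600 nM, a number that lies within the scatter of compound 1 and far above compound 2, which is the only strong inhibitor among the three. The new compound 4, `O=C(NC1CCN(Cc2ccccc2)CC1)c1coc2cc(Br)ccc2c1=O`, arises from compound 3 by bromo in place of methoxy on an aromatic carbon.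

Among the compounds with values here, two steps bear on this change. From a 510-fold lower number from compound 1 to compound 2 (2.70 log units; beyond the scatter), so a large group at this part of the ring can matter enormously. From a 1.6-fold higher number from compound 1 to compound 3 (0.21 log units; within the scatter), so the small methoxy group itself made no difference. Bromo is also a small group, with one heavy atom and no acceptor, so the benzyloxy step offers no direct guide and the methoxy step argues for little movement, perhaps a modest gain.

Compound 4 is therefore expected to give about 8000 nM in this assay, between 1500 nM and 40000 nM. This expected step, a 3.6-fold lower number from compound 3 to compound 4 (0.55 log units; beyond the scatter), is a cautious estimate, since no small substituent other than methoxy has been tested here.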

Compound 4, half-maximal inhibitory concentration: 19700 nM
Estimate against measurement, compound 4: 2.5-fold (0.39 log units) below; low and high end bracket the measured number.
By their numbers in this assay, from the lowest: compound 2; then compounds 1, 4 and 3 (each within the scatter of the next).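

At this position, bromo in place of methoxy gives a 1.5-fold lower number from compound 3 to compound 4 (0.16 log units; within the scatter) in this assay, and bromo in place of hydrogen gives a 1.1-fold higher number from compound 1 to compound 4 (0.05 log units; within the scatter), so neither change moves the number beyond the scatter. Hydrogen, methoxy and bromo therefore read alike at this place, even though methoxy carries a hydrogen-bond acceptor and bromo carries none, and in these three compounds that count does not separate the numbers. Nothing available here explains why these three groups read alike.

The compounds shown leave open whether benzyloxy at this same place would give a number like that of compound 2 at 35 nM, since that compound carries it elsewhere on the ring. Also open, as far as these compounds go, is whether an amine, a carboxylic acid or a longer chain such as butoxy would move the number here.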